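This account rests on a few compounds, and the source may have more. Where it says the series, first, only, none or still open, it means among the compounds named here.

For the measured compounds named here, compound 3 `COc1ccc2nc(Nc3nc(Nc4ccc(S(C)(=O)=O)cc4)ncc3F)sc2c1` stands alone here as the one compound with a measured number: in a functional assay on PC-3 cells (Homo sapiens) for antiproliferative activity, read by MTT assay, with a stated time of 48 h (a lower number here means a stronger inhibitor, a higher number a weaker inhibitor), compound 3 gives 1270 nM. The two other measured compounds sit at a limit of the assay rather than at a number. Compound 1 `Cc1ccc2nc(Nc3nc(Nc4ccc(S(C)(=O)=O)cc4)ncc3F)sc2c1` reaches only the limit > 50000 nM in this assay. Compound 2 `COc1ccc2nc(Nc3nc(Nc4ccc(S(N)(=O)=O)cc4)ncc3F)sc2c1` likewise reaches only the limit > 50000 nM in this assay. The step of an at least 39-fold lower number from compound 1 to compound 3 (1.59 log units; beyond the scatter) follows a methoxy in place of methyl on an aromatic carbon, and the step of an at least 39-fold lower number from compound 2 to compound 3 (1.59 log units; beyond the scatter) follows a methyl in place of amino on a sulfonyl sulfur; both run from the limit of > 50000 nM in this assay, at which 2 of the 3 values shown sit, to a measured number and both lie well beyond the usual scatter.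

Compound 4 `COc1ccc2nc(Nc3ccnc(Nc4ccc(S(C)(=O)=O)cc4)n3)sc2c1` differs from compound 3 by hydrogen in place of fluoro on an aromatic carbon. Going by the values given here, neither measured step touches that position: one concerns the methoxy and the other the sulfonyl group, at the two ends of the shared core, so no measured step bears directly on this change. What the two steps do show is that single small changes in this series can carry the number all the way to the assay limit. With no direct guide, a modest weakening is expected, and compound 4 is estimated at 3500 nM in this assay, within 1000 nM to 15000 nM. For compound 4 this estimate means an expected step of a 2.8-fold higher number from compound 3 to compound 4 (0.44 log units; beyond the scatter).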

Compound 4, half-maximal inhibitory concentration: 2700 nM
Compound 4: the middle estimate sits 1.3-fold (0.11 log units) above what was measured; measured number inside the range.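

For the compounds shown here, replacing the fluoro on the six-membered aromatic ring with 2 nitrogen by hydrogen gives a 2.1-fold higher number from compound 3 to compound 4 (0.33 log units; beyond the scatter) in this assay, the first direct reading at this position. The step is modest but beyond the scatter, so the fluoro has a real influence on the number, yet compound 4 shows that a measured value survives without it. The changes at the methoxy and at the sulfonyl group each lead from compound 3 to a compound at a limit of the assay rather than a number, whereas this change keeps a measured number in place, and the contrast is marked: the limit of > 50000 nM in this assay, at which 2 of the 4 values shown sit.

Only fluoro and hydrogen appear at this position, so the effect of a chloro, a methyl, a nitrile or an amine there remains an open question. The swap is also seen in a single setting, with the methoxy and the methyl on the sulfonyl sulfur in place, so the compounds shown neither tell whether it would move compound 1 or compound 2 away from their limits nor explain why the number shifts at all.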